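Phenyl for trifluoromethyl: from compound 2 to compound 3

The compounds below may be only part of what the source reports. "The series", "measured", "known", "first", "only" and "open" are said of these compounds alone.

In a functional assay on KG-1 cells (Homo sapiens) for cytotoxicity, read by luminescence and CellTiter-Glo, with a stated time of 3 days (on this read-out lower numbers stand for stronger inhibition and higher numbers for weaker inhibition), compound 1 (`N#Cc1ccc(NC(=O)c2ccc(Cl)cc2O)cc1`) gives 1920 nM and compound 2 (`N#Cc1ccc(NC(=O)c2ccc(C(F)(F)F)cc2O)cc1`) gives 1440 nM. Going by the values given here, the only measured step, trifluoromethyl in place of chloro, is a 1.3-fold lower number from compound 1 to compound 2 (0.12 log units; within the scatter), so compound 2 stands level with compound 1. Compound 3 (`N#Cc1ccc(NC(=O)c2ccc(-c3ccccc3)cc2O)cc1`) has phenyl in place of trifluoromethyl on an aromatic carbon. Among the compounds with values here, that one small step is the sole guide, and no measured compound shows a ring entering here, so no shift beyond the scatter is expected. The expected change is a 1.0-fold higher number from compound 2 to compound 3 (0.02 log units; within the scatter). Compound 3 is estimated at 1500 nM, with an expected range of 500 nM to 4500 nM.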

Compound 3, half-maximal inhibitory concentration: 410 nM
The estimate for compound 3 lay 3.7-fold (0.56 log units) above the measured number; the measured number lies below the stated range.
By their numbers in this assay, from the lowest: compound 3; then compounds 2 and 1 (each within the scatter of the next).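

In this assay, this position turns out to respond to the group it carries: phenyl in place of trifluoromethyl gives a 3.5-fold lower number from compound 2 to compound 3 (0.55 log units; beyond the scatter), and phenyl in place of chloro gives a 4.7-fold lower number from compound 1 to compound 3 (0.67 log units; beyond the scatter). Going by these compounds alone, the earlier exchange of chloro for trifluoromethyl, neither of them a ring, had stayed within the scatter, so a six-membered aromatic ring here is the first change to move the number beyond it. No measurement at hand gives a reason for this shift. Going by these compounds, whether a pyridine ring, a cyclohexyl ring or a longer alkyl chain would do the same remains open, as does the effect of a methoxy group on the new phenyl.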